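The compounds below may be only part of what the source reports. "The series", "measured", "known", "first", "only" and "open" are said of these compounds alone.

Compound 1 `ClCc1ccc(Cn2cnc3c(Cl)ncnc32)cc1`: 9330 nM
Compound 2 `ClCc1ccccc1Cn1cnc2c(Cl)nc(Cl)nc21`: 5880 nM

In a functional assay on NCI-H322M cells (Homo sapiens) for cytotoxicity, read by sulforhodamine B assay, with a stated time of 48 h (a higher number here means that more compound is tolerated, a lower number that less compound is tolerated), compound 2 gives the lowest of the two numbers shown, though the gap to compound 1 lies within the scatter. Compound 3 `ClCc1ccccc1Cn1cnc2c(Cl)ncnc21` differs from compound 2 by one change, hydrogen in place of chloro on an aromatic carbon. For the measured compounds named here, no measured pair shows this change, so its size and direction are unknown; the expected step is none beyond the scatter. For compound 3 the estimated value in this assay is 8000 nM, with a range from 3000 nM to 20000 nM. The step of a 1.4-fold higher number from compound 2 to compound 3 (0.13 log units; within the scatter) that this estimate implies is expected to stay within the scatter.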

Compound 3, concentration lethal to 50% of the cells: 43700 nM
The estimate for compound 3 lay 5.5-fold (0.74 log units) below the measured number; the measured number lies above the stated range.
By their numbers in this assay, from the lowest: compounds 2 and 1 (each within the scatter of the next); then compound 3.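

In this assay, putting hydrogen in place of chloro on the aromatic carbon between two ring nitrogen atoms gives a 7.4-fold higher number from compound 2 to compound 3 (0.87 log units; beyond the scatter). For the compounds shown here, this is the first measured size for this change, and it shows that this position is not indifferent: with the chloro there, less compound is tolerated. No measurement shown gives a reason for this step.

From the compounds shown here alone, whether an amine or a methoxy group at this position would stay near compound 2 or near compound 3 remains open. So does whether the step holds in other cell lines.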